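Three cytotoxicity limits and a dichlorobenzyl replacement

This account rests on a few compounds, and the source may have more. Where it says the series, first, only, none or still open, it means among the compounds named here.

Compound 1 `O=[N+]([O-])c1cc(CSc2nnc(C3CCCCC3)n2Cc2ccccc2)cc(C(F)(F)F)c1`, compound 2 `O=[N+]([O-])c1cc(-c2nnc(SCc3ccccc3)n2Cc2ccccc2)cc([N+](=O)[O-])c1` and compound 3 `CCCCCCCCSc1nnc(-c2cc([N+](=O)[O-])cc([N+](=O)[O-])c2)n1Cc1ccccc1` were tested in an ADME assay on HepG2 cells (Homo sapiens) for cytotoxicity, with a stated time of 48 h; on this read-out lower numbers stand for stronger inhibition and higher numbers for weaker inhibition. Compound 1 gives only the assay limit of > 30000 nM. Compound 2 likewise reaches only the limit of > 30000 nM. Compound 3 also stops at the limit of > 30000 nM. Going by the values given here, compound 3 therefore stands where every value so far stands, at the limit of > 30000 nM in this assay, at which 3 of the 3 values shown sit. Among the compounds with values here, the one single-change step, a step that the two limits leave unreadable from compound 2 to compound 3, runs between two limits and is not readable. Compound 4 `O=[N+]([O-])c1cc(-c2nnc(SCc3ccc(Cl)c(Cl)c3)n2Cc2ccccc2)cc([N+](=O)[O-])c1` differs from compound 3 by 3,4-dichlorophenyl in place of heptyl on a saturated chain carbon bound to a sulfur. Within the data shown here, no measured step speaks readably to this change. Compound 4 is expected to show a step that the limit leaves unreadable from compound 3 to compound 4, meaning no readable change in this assay. Compound 4 is estimated at 40000 nM, with a range from 15000 nM to 100000 nM, most likely again only a limit.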

Compound 4, half-maximal inhibitory concentration: > 30000 nM
Compound 4 was reported as a limit; the forecaster's own chance of this, stated with the estimate: 80%; the middle value lies beyond the limit too.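

Compound 4 sits at the same limit as compound 2 and compound 3, so no step to compound 4 can be read: the limit of > 30000 nM in this assay, at which 4 of the 4 values shown sit.

The compounds shown leave open whether any other group at this place would give a measurable number in this assay.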